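From Methyl to Methoxy on the Shared Core

The compounds below may be only part of what the source reports. "The series", "measured", "known", "first", "only" and "open" are said of these compounds alone.

Compound 1 `Nc1ncnc2[nH]cc(Sc3cccs3)c12`: 17900 nM
Compound 2 `Cc1ncnc2[nH]cc(Sc3cccs3)c12`: 14000 nM

Both compounds were tested in a functional assay on K562 cells (Homo sapiens), read by MTT assay, with a stated time of 3 days; on this read-out higher numbers stand for weaker inhibition and lower numbers for stronger inhibition. Compound 2 gives 14000 nM, and its number cannot be told apart from that of compound 1, since the two lie within the usual scatter of repeated measurements. The next compound, compound 3 `COc1ncnc2[nH]cc(Sc3cccs3)c12`, has methoxy in place of methyl on an aromatic carbon. Among the compounds with values here, only one measured step bears on this change, namely a 1.3-fold lower number from compound 1 to compound 2 (0.11 log units; within the scatter). It also exchanges the group on that carbon, and it stayed within the scatter. A single step is thin evidence, but it gives no reason to expect a large move in this assay, in either direction. The expected step is a 1.1-fold higher number from compound 2 to compound 3 (0.03 log units; within the scatter), which would be no change beyond the scatter. For compound 3 the estimated value is 15000 nM, with an expected range of 7000 nM to 32000 nM.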

Compound 3, half-maximal inhibitory concentration: > 50000 nM
Compound 3: no number, only a limit; the forecaster's own chance of this, stated with the estimate: 7%; middle value at least 3.3-fold (0.52 log units) from the limit.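

In this assay, within the data shown here, the group on this aromatic carbon does make a difference, which the earlier compounds gave no sign of: methoxy in place of methyl gives an at least 3.5-fold higher number from compound 2 to compound 3 (0.55 log units; beyond the scatter), and methoxy in place of amino gives an at least 2.7-fold higher number from compound 1 to compound 3 (0.44 log units; beyond the scatter). Both of these steps lie beyond the scatter and point towards weaker inhibition, whereas the exchange of amino for methyl, a 1.3-fold lower number from compound 1 to compound 2 (0.11 log units; within the scatter), stayed within it. For compound 3 the reading is a limit of the assay and not a number: the limit of > 50000 nM in this assay, at which 1 of the 3 values shown sits.

Going by these compounds, only a lower end is known for both steps, so their true size remains open. On these data alone, it also remains open whether a longer group such as ethoxy, or a hydroxyl or a chlorine on this carbon, would fall with methoxy or with methyl and amino.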